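This account rests on a few compounds, and the source may have more. Where it says the series, first, only, none or still open, it means among the compounds named here.

In a functional assay on HL-60 cells (Homo sapiens) for activation, read by flow cytometry, with a stated time of 4 days (a lower number here means that less compound is needed, a higher number that more compound is needed for the effect), compound 1 (`COc1ccc(-n2cnc3cnc(Nc4cccc(NC(C)=O)c4)cc32)cc1OC`) gives 140 nM and compound 2 (`COc1ccc(-n2cnc3cnc(Nc4cccc(NS(C)(=O)=O)c4)cc32)cc1OC`) gives 6900 nM. Compound 3 (`COc1ccc(-n2cnc3cnc(-c4cccc(NC(C)=O)c4)cc32)cc1OC`) gives > 30000 nM, which is a limit of the assay and not a number; this is the limit of > 30000 nM in this assay, at which 1 of the 3 values shown sits. Compound 4 (`COc1ccc(-n2cnc3cnc(-c4ccccc4)cc32)cc1OC`) carries hydrogen in place of acetamido on an aromatic carbon. Among the measured compounds shown here, the only measured step that bears on this is a 49-fold higher number from compound 1 to compound 2 (1.69 log units; beyond the scatter). For the measured compounds named here, it is large, but it shows only that a change on that nitrogen substituent can move the number in this assay. A step starting from a limit has no measured size, so no shift beyond the scatter is expected. The expected step is a number no higher from compound 3 to compound 4 (the limit leaves the size open), and another limit reading is likely. For compound 4 the estimate is 30000 nM, with an expected range from 8000 nM to 60000 nM.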

Compound 4, half-maximal effective concentration: 1600 nM
The estimate for compound 4 lay 19-fold (1.27 log units) above the measured number; measured number below the stated range.
By their numbers in this assay, from the lowest: compound 1; then compound 4; then compound 2. At a limit, above all of these: compound 3.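

In this assay, hydrogen in place of acetamido on this aromatic carbon gives an at least 18-fold lower number from compound 3 to compound 4 (1.27 log units; beyond the scatter). The reading for compound 3 is a limit and not a number: the limit of > 30000 nM in this assay, at which 1 of the 4 values shown sits. Compound 1 and compound 2 showed only a change on the nitrogen substituent, whereas this step shows that, in the frame of compound 3, the acetamido group is not needed for a reading below the limit, and that removing it whole lowers the number.

Still open, going by these compounds, is where a small group on this carbon, such as an amine or a hydroxyl, would fall relative to compound 4. Also open, on these data alone, is whether the same exchange on compound 1 would move the number in the same direction.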